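From Phenyl to Pyridin-2-yl on an Amine Nitrogen

A few compounds are considered here, and "the series" means these few. Any claim that something is new, unique, unknown or untested is made for them only; others in the source may bear on it.

Of the compounds shown here, three have been measured in a physicochemical assay for lipophilicity, read by HPLC; on this read-out higher numbers stand for higher lipophilicity and lower numbers for lower lipophilicity. Compound 1 (`COc1ccc(NC[C@H](O)COc2ccc(N3C[C@H](CNC(C)=O)OC3=O)cc2F)cc1`) gives 0.95, and compound 3 (`CC(=O)NC[C@H]1CN(c2ccc(OC[C@@H](O)CNc3cc(C(F)(F)F)cc(C(F)(F)F)c3)c(F)c2)C(=O)O1`) gives 3.1. Compound 2 (`CC(=O)NC[C@H]1CN(c2ccc(OC[C@H](O)CNc3ccccc3)c(F)c2)C(=O)O1`) stands lowest of the three at 0.59, and both of the others lie above it by more than the scatter of repeated measurements. Compound 4 (`CC(=O)NC[C@H]1CN(c2ccc(OC[C@H](O)CNc3ccccn3)c(F)c2)C(=O)O1`) has not yet been measured. It carries pyridin-2-yl in place of phenyl on an amine nitrogen. Going by the values given here, no measured pair shows this change, so the expectation rests on the structural change alone. A modest drop in this assay is expected, slightly beyond the scatter, and the estimated step is a number 0.39 log units lower from compound 2 to compound 4 (beyond the scatter). For compound 4 the expected value is 0.2, with an estimated range of -0.2 to 0.6.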

Compound 4, partition coefficient: 1.6
Compound 4: middle estimate off by 1.40 log units, on the low side, and the stated range ends below it.
By their numbers in this assay, from the lowest: compound 2; then compound 1; then compound 4; then compound 3.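

Pyridin-2-yl in place of phenyl on an amine nitrogen gives the first step that can be read at a single place, and in this assay it comes out as a number 1.01 log units higher from compound 2 to compound 4 (beyond the scatter). The entering group counts one hydrogen-bond acceptor where phenyl counts none, yet the number goes up at this position. Nothing measured here explains the direction of this step. Going by these compounds, whether pyridin-3-yl or pyrimidin-2-yl on the same amine nitrogen would move the number the same way remains open. So does the effect of a methoxy group on the pyridin-2-yl.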